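The source may hold more compounds than are shown below. What is called first, only, known or untested is meant among the compounds shown, and "the series" means these compounds.

Measured compounds:
- compound 1, `CC(C)[C@]1(c2ccccc2)OC[C@H]([C@@H]2CCCCN2)O1`: 45 nM
- compound 2, `CC[C@]1(c2ccc(Cl)cc2)OC[C@H]([C@@H]2CCCCN2)O1`: 2800 nM
- compound 3, `CC[C@]1(c2cccc(N)c2)OC[C@H]([C@@H]2CCCCN2)O1`: 1230 nM

All three share one core and differ in the groups on its aromatic ring and in the small alkyl chain. In a functional assay (brain) for displacement of a labelled ligand, with Rattus norvegicus as the target (a lower number here means a stronger inhibitor, a higher number a weaker inhibitor), compound 2 gives 2800 nM, the highest number of the three and therefore the weakest inhibitor shown. Its closest neighbour is compound 3, which in this assay gives 1230 nM, a gap beyond the scatter. Far stronger is compound 1, which in this assay gives 45 nM, and it carries no group on its aromatic ring at all.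

Compound 4, `CC[C@]1(c2ccc(F)cc2)OC[C@H]([C@@H]2CCCCN2)O1`, differs from compound 2 in one place: fluoro in place of chloro on an aromatic carbon. Within the data shown here, no measured pair shows this exact exchange, so the size of the step must be guessed. Among the measured compounds shown here, the only hint is compound 1, whose ring bears no such group and whose value of 45 nM is much lower. For compound 4 the expected step is a 1.9-fold lower number from compound 2 to compound 4 (0.27 log units; within the scatter), a modest move down, close to the scatter. In this assay compound 4 is expected to give about 1500 nM, with a likely range from 500 nM to 5000 nM.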

Compound 4, inhibition constant: 649 nM
Beside the measured number, compound 4's estimate is 2.3-fold (0.36 log units) above it, and the stated range covers the measured number.
By their numbers in this assay, from the lowest: compound 1; then compounds 4 and 3 (each within the scatter of the next); then compound 2.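

In this assay, among these compounds, fluoro in place of chloro on the aromatic carbon para to a large group gives a 4.3-fold lower number from compound 2 to compound 4 (0.63 log units; beyond the scatter), the only change between these two compounds. This shows that the number responds to which halogen sits at this position, even though the exchange swaps one heavy atom for one heavy atom and neither group counts any hydrogen-bond donors or acceptors. No measurement shown here explains why the number moves.

Still open, on these data alone, is how bromo, methoxy or nitrile at this same position would compare with fluoro and chloro, and what a bare hydrogen there would give on an otherwise identical compound. It is also unknown whether the exchange would give a similar step with a longer chain in place of the small alkyl chain.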